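Removing the chloro from an inactive carbamothioate

The compounds below may be only part of what the source reports. "The series", "measured", "known", "first", "only" and "open" are said of these compounds alone.

Of the compounds shown here, three have been tested in a functional assay on OVCAR-3 cells (Homo sapiens) for cytotoxicity, read by MTT assay, with a stated time of 6 days; a lower number here means a stronger inhibitor, a higher number a weaker inhibitor. Compound 1 `CC(=O)N[C@@H](CSC(=O)NCc1ccc(Cl)cc1)C(=O)O` is a carbamothioate built on an acetylated cysteine; in this assay compound 1 gives > 200000 nM, which is a limit of the assay rather than a number. Compound 2 `COc1ccccc1CNC(=O)SC[C@H](NC(C)=O)C(=O)O` carries a methoxy-substituted benzyl group; in this assay compound 2 gives > 200000 nM, again a limit. Compound 3 `CC(=O)N[C@@H](CSC(=O)Nc1ccc(Cl)cc1)C(=O)O` has the chlorophenyl attached directly to the nitrogen; in this assay compound 3 gives > 200000 nM, which is also a limit and not a number. So compound 3 stands exactly where the other two stand, at the limit of > 200000 nM in this assay, at which 3 of the 3 values shown sit.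

The next compound, compound 4 `CC(=O)N[C@@H](CSC(=O)Nc1ccccc1)C(=O)O`, differs from compound 3 by hydrogen in place of chloro on an aromatic carbon. The step from compound 3 to compound 4 cannot be measured in size here, since compound 3 only has a limit; the expected outcome is that compound 4 also stays at the limit, so the expected step from compound 3 to compound 4 is a step that the limit leaves unreadable from compound 3 to compound 4, no more than the scatter. The estimate for compound 4 is 300000 nM, with a range from 150000 nM to 1000000 nM.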

Compound 4, half-maximal inhibitory concentration: 153000 nM
Compound 4: the middle estimate sits 2.0-fold (0.29 log units) above what was measured; the measured number falls inside the stated range.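

Within the data shown here, compound 4 is the first compound in this assay to give a real number rather than a limit: the limit of > 200000 nM in this assay, at which 3 of the 4 values shown sit. Hydrogen in place of chloro gives an at least 1.3-fold lower number from compound 3 to compound 4 (0.11 log units; that floor lies within the scatter). The value for compound 3 is only a limit, so the true step could be larger, but what can be read here does not show that removing the chloro changes anything, and compound 4 remains a very weak inhibitor.

The compounds shown leave open whether any group at this place on the ring, such as an amine or a nitrile, would move the number well beyond the scatter. They also leave open whether a longer chain between the ring and the nitrogen would do so.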